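Fluoro in place of chloro: compound 2 to compound 4

A few compounds are considered here, and "the series" means these few. Any claim that something is new, unique, unknown or untested is made for them only; others in the source may bear on it.

Of the compounds shown here, three have numbers so far in an ADME assay on RAW264.7 cells (Mus musculus) for cytotoxicity, read by trypan blue exclusion, with a stated time of 48 h (a lower number here means a stronger inhibitor of growth, a higher number a weaker inhibitor of growth), as the read-out for this series. Compound 1 `Cc1cc(CNCc2ccccc2)c(C)n1-c1ccc(F)cc1` reads 5.6 ug/mL and compound 3 `Cc1cc(CNCc2ccccc2)c(C)n1-c1ccc(Cl)cc1` reads 5.5 ug/mL as its value. Compound 2 `Cc1cc(CNOCc2ccccc2)c(C)n1-c1ccc(Cl)cc1` reads 133 ug/mL as the highest number of the three.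

Compound 4 `Cc1cc(CNOCc2ccccc2)c(C)n1-c1ccc(F)cc1` is the next to be read and departs from compound 2 by a single change. The change fluoro in place of chloro on an aromatic carbon sits on an aromatic carbon of a six-membered aromatic ring of carbon only, para to a large group, and reads as 4-chlorophenyl to 4-fluorophenyl.

Within the data shown here, the one measured swap of these two halogens runs the reverse way, chloro in place of fluoro, and gives a 1.0-fold lower number from compound 1 to compound 3 (0.01 log units; within the scatter) with benzyl on the amine nitrogen. The other measured step, benzyl in place of benzyloxy, gives a 24-fold lower number from compound 2 to compound 3 (1.38 log units; beyond the scatter) as a large step, but benzyloxy stays in place in compound 4. Among the measured compounds shown here, no measured pair shows the halogen swap with benzyloxy on the amine nitrogen, so its carry-over remains untested.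

No step beyond the scatter is therefore expected in either direction, and the estimated outcome is a 1.0-fold lower number from compound 2 to compound 4 (0.01 log units; within the scatter) with neither direction favoured. For compound 4 the expected value is 130 ug/mL with an estimated range of 60 ug/mL to 280 ug/mL once it is measured.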

Compound 4, concentration for 50% growth inhibition: 123 ug/mL
For compound 4 the middle estimate is 1.1-fold (0.02 log units) above the measured one; the measured number falls inside the stated range.
By their numbers in this assay, from the lowest: compounds 3 and 1 (each within the scatter of the next); then compounds 4 and 2 (each within the scatter of the next).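

In this assay, the change from 4-chlorophenyl to 4-fluorophenyl now has a reading with benzyloxy on the amine nitrogen, a 1.1-fold lower number from compound 2 to compound 4 (0.03 log units; within the scatter), so the halogen swap stays within the scatter with either group on that nitrogen: the same change on two cores in this assay, a 1.0-fold lower number (0.01 log units; within the scatter) from compound 1 to compound 3 and a 1.1-fold higher number (0.03 log units; within the scatter) from compound 4 to compound 2, 1.1-fold (0.04 log units) apart, within the scatter of two such steps

The large step tied to the amine nitrogen also now appears with fluoro as well as chloro on the aromatic carbon, a 22-fold higher number from compound 1 to compound 4 (1.34 log units; beyond the scatter), and its size holds across the two halogens: the same change on two cores in this assay, a 24-fold lower number (1.38 log units; beyond the scatter) from compound 2 to compound 3 and a 22-fold lower number (1.34 log units; beyond the scatter) from compound 4 to compound 1, 1.1-fold (0.04 log units) apart, within the scatter of two such steps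

Across these four compounds, the group on the amine nitrogen separates the numbers while the swap between these two halogens does not, and no compound shown goes against this.

The compounds shown leave open whether a group other than chloro or fluoro at this aromatic carbon, such as methoxy, a nitrile or a carboxylic acid, would shift the number in this assay with either group on the nitrogen. They also leave open where a longer chain such as phenethyl on the amine nitrogen would fall relative to benzyl and benzyloxy, and what underlies the large step remains unresolved.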